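This account rests on a few compounds, and the source may have more. Where it says the series, first, only, none or still open, it means among the compounds named here.

Among the measured compounds shown here, compound 3 `COc1ccc(C(=O)/C=C/c2ccc(OCc3cn(Cc4ccccc4)nn3)cc2)cc1` stands highest of the three numbers measured so far: in a functional assay on HepG2 cells (Homo sapiens) for inhibition, read by MTT assay, with a stated time of 48 h, tested at 10 uM (a lower number here means less inhibition of growth, a higher number more inhibition of growth at the concentration tested), compound 3 gives 51%. Compound 1 `O=C(/C=C/c1ccc(OCc2cn(Cc3ccccc3)nn2)cc1)c1ccc(Br)cc1` gives 22% and compound 2 `O=C(/C=C/c1ccc(OCc2cn(Cc3ccc(Br)cc3)nn2)cc1)c1ccc(Br)cc1` gives 22%. The rise a number 29 percentage points higher from compound 1 to compound 3 (beyond the scatter) came with a methoxy in place of bromo, while the change no change at the digits printed from compound 1 to compound 2 (within the scatter) came with a bromo entering at a different place. Compound 4 `COc1ccc(C(=O)/C=C/c2ccc(OCc3cn(Cc4ccccc4F)nn3)cc2)cc1` differs from compound 3 by fluoro in place of hydrogen on an aromatic carbon. For the measured compounds named here, only the step from compound 1 to compound 2 bears on this, since there too a halogen entered the benzyl ring, and that step showed nothing beyond the scatter. Compound 4 is therefore expected to give about 50%, with a likely range from 35% to 65%. The expected step is a number 1 percentage points lower from compound 3 to compound 4 (within the scatter), nothing beyond the scatter.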

Compound 4, percent growth inhibition at one concentration: 33%
Compound 4: the middle estimate sits 17 percentage points above what was measured, outside the stated range (below it).
By their numbers in this assay, from the lowest: compounds 1 and 2 (each within the scatter of the next); then compound 4; then compound 3.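

Placing one fluoro on the benzyl ring, ortho to a large group, gives a number 18 percentage points lower from compound 3 to compound 4 (beyond the scatter) in this assay, so even the smallest halogen change on this ring can register. The earlier bromo step gave no change at the digits printed from compound 1 to compound 2 (within the scatter) and so had not shown this ring to respond to a halogen. Nothing available here explains the drop. Still open, going by these compounds, is whether a chloro, a methyl or an amine at this same place would lower the number too. Also open, on these data alone, is whether 2-fluorobenzyl would do the same on compound 1.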